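Swapping isopropyl for 2-hydroxyethyl in compound 1

The compounds below may be only part of what the source reports. "The series", "measured", "known", "first", "only" and "open" are said of these compounds alone.

For the measured compounds named here, measured in an ADME assay on microsomes from liver (Homo sapiens) for metabolic stability (on this read-out higher numbers stand for fast clearance and lower numbers for slow clearance), compound 1 (`CC(C)ON(C)C(=O)c1n[nH]c2c1CN(C(=O)Nc1cccc(Cl)c1)CC2`) gives 65 mL/min/kg and holds the higher of the two numbers known so far. Compound 2 (`CN(OC1COC1)C(=O)c1n[nH]c2c1CN(C(=O)Nc1cccc(Cl)c1)CC2`) carries oxetan-3-yl in place of isopropyl on an oxygen and gives 8 mL/min/kg in this assay on the same core. Going by the values given here, that change is an 8.1-fold lower number from compound 1 to compound 2 (0.91 log units; beyond the scatter) and it is the only measured step at this place. Compound 3 (`CN(OCCO)C(=O)c1n[nH]c2c1CN(C(=O)Nc1cccc(Cl)c1)CC2`) is still unmeasured and differs from compound 1 as follows: 2-hydroxyethyl in place of isopropyl on an oxygen. Here 2-hydroxyethyl, which has no ring, enters in place of isopropyl on the same oxygen. A single step is thin evidence, but an 8.1-fold lower number from compound 1 to compound 2 (0.91 log units; beyond the scatter) points to a lower number in this assay and a somewhat smaller change is expected for the open chain. The expected step is a 3.6-fold lower number from compound 1 to compound 3 (0.56 log units; beyond the scatter). Compound 3 is estimated at 18 mL/min/kg with an expected range of 8 mL/min/kg to 40 mL/min/kg.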

Compound 3, clearance: 31 mL/min/kg
Beside the measured number, compound 3's estimate is 1.7-fold (0.24 log units) below it; measured number inside the range.
By their numbers in this assay, from the lowest: compound 2; then compound 3; then compound 1.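

In this assay, the open-chain 2-hydroxyethyl group also lowers the number relative to isopropyl (a 2.1-fold lower number from compound 1 to compound 3 (0.32 log units; beyond the scatter)), so among the groups shown at this oxygen, a ring is not required for a drop in clearance. The two replacements are not equivalent, however: 2-hydroxyethyl in place of oxetan-3-yl gives a clear rise (a 3.9-fold higher number from compound 2 to compound 3 (0.59 log units; beyond the scatter)), which leaves the ring-bearing compound 2 with the lowest number of the three. Nothing measured here accounts for this difference between the groups.

The compounds shown leave open whether 2-methoxyethyl or a longer chain such as 3-hydroxypropyl would sit closer to compound 2 or to compound 1. They also leave open whether a ring without oxygen, such as cyclobutyl, would keep the number as low as oxetan-3-yl does.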